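This account rests on a few compounds, and the source may have more. Where it says the series, first, only, none or still open, it means among the compounds named here.

Compound 1 `CC(O)(CSc1cccc(S(F)(F)(F)(F)F)c1)C(=O)Nc1ccc([N+](=O)[O-])c(C(F)(F)F)c1`: 13900 nM
Compound 2 `CC(O)(COc1cccc(C(F)(F)F)c1)C(=O)Nc1ccc(S(F)(F)(F)(F)F)cc1`: 21900 nM
Compound 3 `CC(O)(COc1ccccc1C(F)(F)F)C(=O)Nc1ccc(S(F)(F)(F)(F)F)cc1`: 7100 nM

In a functional assay on DU-145 cells (Homo sapiens) for antiproliferative activity, read by propidium iodide staining, with a stated time of 96 h (on this read-out higher numbers stand for weaker inhibition and lower numbers for stronger inhibition), compound 3 gives 7100 nM. That number lies within the usual scatter of the value for compound 1, and it is clearly lower than the value for compound 2, as the step of a 3.1-fold lower number from compound 2 to compound 3 (0.49 log units; beyond the scatter) shows.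

The next compound, compound 4 `CC(O)(COc1ccccc1OC(F)(F)F)C(=O)Nc1ccc(S(F)(F)(F)(F)F)cc1`, carries trifluoromethoxy in place of trifluoromethyl on an aromatic carbon.

Going by the values given here, only one measured step bears on this change, the modest 3.1-fold lower number from compound 2 to compound 3 (0.49 log units; beyond the scatter). That step shifts where the trifluoromethyl group sits and does not exchange the group for another, so it shows only that this part of the molecule can move the number somewhat. Among the compounds with values here, no measured pair tests trifluoromethoxy against trifluoromethyl, so no direction can be argued from the data, and no change beyond the scatter is expected in this assay. The expected step is a 1.1-fold higher number from compound 3 to compound 4 (0.02 log units; within the scatter).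

For compound 4 the estimated value is 7500 nM, with an expected range from 3000 nM to 18000 nM.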

Compound 4, half-maximal inhibitory concentration: 16800 nM
Beside the measured number, compound 4's estimate is 2.2-fold (0.35 log units) below it, and the stated range covers the measured number.
By their numbers in this assay, from the lowest: compounds 3, 1, 4 and 2 (each within the scatter of the next, the first and the last beyond it).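

In this assay, the group itself at this place matters, and not only where it sits on the ring: the earlier step moved trifluoromethyl around the ring, whereas here, on an aromatic carbon ortho to a large group, trifluoromethoxy replaces trifluoromethyl and gives a 2.4-fold higher number from compound 3 to compound 4 (0.37 log units; beyond the scatter). In this single pair, the group with the added oxygen is the less favourable choice, although the step is modest and does not show that activity is lost. Nothing available explains the shift.

These compounds leave open whether the trend extends to other groups at this place, such as a nitrile, a chlorine atom or a plain methoxy group. They also leave open whether the same exchange would have a similar effect with the group at the other ring position seen in compound 2.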